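From hydroxy to methoxy on compound 1

The source may report more compounds than this note shows. Statements on the series, on what has been measured and on what is new or still open speak of the compounds shown alone.

In a functional assay on PC-3 cells (Homo sapiens) for antiproliferative activity, read by sulforhodamine B assay, with a stated time of 48 h (a lower number here means a stronger inhibitor, a higher number a weaker inhibitor), compound 1 `O=C(NCCCNc1cc(-c2cn(-c3ccccc3)nc2-c2cccc(O)c2)ccn1)Nc1ccc(F)cc1` gives 1330 nM and compound 2 `O=C(NCCCNc1cc(-c2cn(-c3ccccc3)nc2-c2cccc(O)c2)ccn1)Nc1cccc(C(F)(F)F)c1` gives 1790 nM, so the two stand level within the scatter. Compound 3 `COc1cccc(-c2nn(-c3ccccc3)cc2-c2ccnc(NCCCNC(=O)Nc3ccc(F)cc3)c2)c1` departs from compound 1 through (methyl in place of hydrogen on an oxygen on an aromatic ring), turning 3-hydroxyphenyl into 3-methoxyphenyl. Going by the values given here, the only measured step, a 1.3-fold higher number from compound 1 to compound 2 (0.13 log units; within the scatter), exchanges a different group, on an amide-type nitrogen, so it says nothing directly about this change. No clear direction can be drawn from it, and no shift beyond the scatter is expected. The estimated step is a 1.3-fold higher number from compound 1 to compound 3 (0.11 log units; within the scatter). For compound 3 the expected value is 1700 nM, with an estimated range from 650 nM to 4500 nM.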

Compound 3, half-maximal inhibitory concentration: 6230 nM
Compound 3: middle estimate off by 3.7-fold (0.56 log units), on the low side; measured number outside the range, above it.
By their numbers in this assay, from the lowest: compounds 1 and 2 (each within the scatter of the next); then compound 3.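

In this assay, methyl in place of hydrogen on this oxygen gives a 4.7-fold higher number from compound 1 to compound 3 (0.67 log units; beyond the scatter), so the 3-methoxyphenyl compound is the weaker inhibitor. The only earlier step, on the amide-type nitrogen, stayed within the scatter, which makes this oxygen the first place shown where a single change moves the number beyond it. Nothing available accounts for the loss. Still open, going by these compounds, is whether an amine in place of the hydroxy, or an ethoxy group, would behave like hydroxy or methoxy. On these data alone, whether the same loss appears with the 3-(trifluoromethyl)phenyl group of compound 2 also remains unknown.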